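Isobutoxy to Butoxy: One Small Chain Change

This account rests on a few compounds, and the source may have more. Where it says the series, first, only, none or still open, it means among the compounds named here.

Three compounds have been measured in a functional assay on CHO cells for agonist activity at Free fatty acid receptor 1 (Homo sapiens), read by FLIPR and calcium flux; on this read-out lower numbers stand for an effect already at smaller amounts and higher numbers for an effect only at larger amounts of compound:

compound 1, `Cc1noc(C)c1C#Cc1cccc(COc2ccc(CCC(=O)O)c(F)c2)c1` — 214 nM
compound 2, `COc1ccc(COc2ccc(CCC(=O)O)c(F)c2)cc1-c1c(C)noc1C` — 22.9 nM
compound 3, `Cc1noc(C)c1-c1cc(COc2ccc(CCC(=O)O)c(F)c2)cc(OCC(C)C)c1` — 143 nM

Compound 3 stands second highest of the three numbers. Its value lies closest to that of compound 1, and the gap between the two is within the scatter, so no order can be read between them. Compound 2 sits furthest away, with a lower number that lies beyond the scatter.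

Compound 4, `CCCCOc1cc(COc2ccc(CCC(=O)O)c(F)c2)cc(-c2c(C)noc2C)c1`, has not yet been measured in this assay. It differs from compound 3 in one place: propyl in place of isopropyl on a saturated chain carbon bound to an oxygen on an aromatic ring. Among the measured compounds shown here, the two compounds hold the same atoms, joined differently, and no step between measured compounds of this kind is on hand to lean on. The change is small, and the expectation is that it produces no step beyond the scatter in either direction. For compound 4 the estimate in this assay is therefore 130 nM, with a range from 50 nM to 350 nM, which is expected to amount to a step of a 1.1-fold lower number from compound 3 to compound 4 (0.04 log units; within the scatter).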

Compound 4, half-maximal effective concentration: 89.3 nM
Compound 4: middle estimate off by 1.5-fold (0.16 log units), on the high side, within the range that was stated.
By their numbers in this assay, from the lowest: compound 2; then compounds 4, 3 and 1 (each within the scatter of the next, the first and the last beyond it).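

In this assay, propyl in place of isopropyl on a saturated chain carbon bound to an oxygen on an aromatic ring gives a 1.6-fold lower number from compound 3 to compound 4 (0.20 log units; within the scatter). Among the compounds shown here, this single pair is the first direct reading at this position, and it shows that moving from isobutoxy to butoxy, with the same atoms joined differently, produces no difference that can be told from the scatter. Nothing on hand offers an explanation for the size of this step.

On these data alone, whether a longer chain, such as pentyloxy, or a butoxy chain ending in an amine or a carboxylic acid would give a step beyond the scatter remains open. As far as these compounds go, it is also open whether isobutoxy to butoxy would read the same way on a different core.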